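The compounds below may be only part of what the source reports. "The series", "measured", "known", "first", "only" and "open" are said of these compounds alone.

Working notes on the series. Among the compounds with values here, in an ADME assay on a cell-free system (plasma, Mus musculus) for metabolic stability, read by LC-MS, tested at 2 uM (a lower number here means that the compound disappears faster, a higher number that the compound lasts longer), compound 1 `CN1CCC(c2ccc3c(c2)oc(=O)n3C(=O)NCCCCc2ccc(F)cc2)CC1` gives 0.333 h, the only actual number so far. Compound 2 `CN1CCN(c2ccc3c(c2)oc(=O)n3C(=O)NCCCCc2ccccc2)CC1` reads < 0.0834 h, which is a limit of the assay. Compound 3 `CCN1CCN(c2ccc3c(c2)oc(=O)n3C(=O)NCCCCc2ccccc2)CC1` reads < 0.0834 h, also a limit. The evidence is therefore thin: the limit of < 0.0834 h in this assay, at which 2 of the 3 values shown sit. Within the data shown here, the one measured step, a step that the two limits leave unreadable from compound 2 to compound 3, has no readable size and concerns a carbon bound to an amine nitrogen in a ring, not the chain.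

Compound 4 `CCCCCNC(=O)n1c(=O)oc2cc(C3CCN(C)CC3)ccc21` differs from compound 1 as follows: methyl in place of 4-fluorophenyl on a saturated chain carbon, four bonds along the chain from an amide-type nitrogen. This puts methyl in place of 4-fluorophenyl on a saturated chain carbon, four bonds along the chain from an amide-type nitrogen. Among the measured compounds shown here, no measured step bears on this change, so no shift beyond the scatter is expected in this assay, and no direction can be assigned. The estimated outcome is a 1.1-fold lower number from compound 1 to compound 4 (0.05 log units; within the scatter). Compound 4 is expected at 0.3 h, with an estimated range of 0.1 h to 0.9 h.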

Compound 4, half-life: 1.25 h
Compound 4: the middle estimate sits 4.2-fold (0.62 log units) below what was measured; measured number above the stated range.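

In this assay, the 4-fluorophenyl group is not required for the compound to last: with methyl in its place, on a saturated chain carbon, four bonds along the chain from an amide-type nitrogen, the result is a 3.8-fold higher number from compound 1 to compound 4 (0.57 log units; beyond the scatter). Within the data shown here, this is the first readable step, and it concerns the chain, whereas the earlier pair concerned a carbon bound to an amine nitrogen in a ring. No measurement shown gives a reason for this step.

The 4-fluorophenyl group leaves as a whole, so the compounds shown do not tell whether the step rests on the fluorine, on the ring or on the whole group. Where a cyclohexyl group or a longer chain such as hexyl would fall at this place remains open, as does whether the step holds on a different core.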